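The compounds below may be only part of what the source reports. "The series", "measured", "known", "first", "only" and "open" are said of these compounds alone.

Measured so far in a functional assay on A549 cells (Homo sapiens) for inhibition, read by MTT assay, with a stated time of 72 h; on this read-out higher numbers stand for weaker inhibition and lower numbers for stronger inhibition:
- compound 1 `CC(C)=CCC/C(C)=C/COc1ccc(C2CC2C(=O)NNC(=O)c2ccncc2)cc1` gives 78000 nM
- compound 2 `O=C(NNC(=O)C1CC1c1ccc(OCC(F)(F)F)cc1)c1ccncc1` gives 10000 nM

Going by the values given here, compound 2 holds the lowest of the two numbers; the only step measured, a 7.8-fold lower number from compound 1 to compound 2 (0.89 log units; beyond the scatter), separates it from compound 1. Compound 3 `COc1ccc(C2CC2C(=O)NNC(=O)c2ccncc2)cc1` carries hydrogen in place of trifluoromethyl on a saturated chain carbon bound to an oxygen on an aromatic ring. That single step bears on it only loosely: it concerns a different group leaving the same place, so its direction cannot simply be carried over. A step of at most modest size is expected, a 1.2-fold higher number from compound 2 to compound 3 (0.08 log units; within the scatter), leaning toward no change beyond the scatter. Compound 3 is therefore estimated at 12000 nM, in the range 4000 nM to 36000 nM.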

Compound 3, half-maximal inhibitory concentration: > 100000 nM
Compound 3: a limit, no number; the forecaster's own chance of this, stated with the estimate: 10%; middle value at least 8.3-fold (0.92 log units) away from the limit.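

In this assay compound 3 gives > 100000 nM, a limit of the assay and not a number. Hydrogen in place of trifluoromethyl gives an at least 10-fold higher number from compound 2 to compound 3 (1.00 log units; beyond the scatter), so this place does not tolerate every change, and 2,2,2-trifluoroethoxy reads clearly better than methoxy. Hydrogen in place of 2,6-dimethylhepta-1,5-dien-1-yl gives only a floor, an at least 1.2-fold higher number from compound 1 to compound 3 (0.10 log units; that floor lies within the scatter), so the order of compound 1 and compound 3 stays unresolved.

The compounds shown leave open whether the fluorine atoms or the added chain carbon carry the difference. An ethoxy group at this place would separate the two.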